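The source may hold more compounds than are shown below. What is called first, only, known or untested is meant among the compounds shown, and "the series" means these compounds.

Series notes. Compound 1 `COc1cc(-c2nc(-c3ccccc3)[nH]c2-c2ccnc(NCCCNS(=O)(=O)c3ccc(C(F)(F)F)cc3)n2)ccc1F` in a functional assay on LOX IMVI cells (Homo sapiens) for cytotoxicity, read by MTT assay, with a stated time of 24 h (a higher number here means a weaker inhibitor, a lower number a stronger inhibitor), gives 75200 nM. Compound 2 `COc1cc(-c2nc(-c3ccccc3)[nH]c2-c2ccnc(NCCCNS(=O)(=O)c3cccc(F)c3)n2)ccc1F` gives 900 nM. Compound 3 `COc1cc(-c2nc(-c3ccccc3)[nH]c2-c2ccnc(NCCCNS(=O)(=O)c3ccc(C(F)(F)F)cc3)n2)ccc1Cl` gives 1780 nM. Compound 4 `COc1cc(-c2nc(-c3ccccc3)[nH]c2-c2ccnc(NCCCNS(=O)(=O)c3cccc(F)c3)n2)ccc1Cl` has not yet been measured in this assay. The two cores differ as chloro in place of fluoro on an aromatic carbon, which made a step of a 42-fold lower number from compound 1 to compound 3 (1.63 log units; beyond the scatter). The change from compound 3 to compound 4 is 3-fluorophenyl in place of 4-(trifluoromethyl)phenyl on a sulfonyl sulfur; the same change has been seen once already, as 3-fluorophenyl in place of 4-(trifluoromethyl)phenyl on a sulfonyl sulfur, where it made a step of an 84-fold lower number from compound 1 to compound 2 (1.92 log units; beyond the scatter). Compound 2 and compound 3 sit close to one another. A smaller step than the earlier one is expected for compound 4, a 4.5-fold lower number from compound 3 to compound 4 (0.65 log units; beyond the scatter), since the large earlier step started from compound 1 at 75200 nM while compound 3 already stands at 1780 nM. Compound 4 is expected at 400 nM, with a range from 40 nM to 4000 nM.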

Compound 4, half-maximal inhibitory concentration: 5110 nM
The estimate for compound 4 lay 13-fold (1.11 log units) below the measured number; the whole stated range lies below it.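

On the core of compound 3, 3-fluorophenyl in place of 4-(trifluoromethyl)phenyl on a sulfonyl sulfur gives a 2.9-fold higher number from compound 3 to compound 4 (0.46 log units; beyond the scatter) in this assay, so this change does not carry over from the core of compound 1 in size or in direction: the same change on two cores in this assay, an 84-fold lower number (1.92 log units; beyond the scatter) from compound 1 to compound 2 and a 2.9-fold higher number (0.46 log units; beyond the scatter) from compound 3 to compound 4, 240-fold (2.38 log units) apart, beyond the scatter of two such steps. Chloro in place of fluoro on an aromatic carbon likewise reverses direction, with a 5.7-fold higher number from compound 2 to compound 4 (0.75 log units; beyond the scatter): the same change on two cores in this assay, a 42-fold lower number (1.63 log units; beyond the scatter) from compound 1 to compound 3 and a 5.7-fold higher number (0.75 log units; beyond the scatter) from compound 2 to compound 4, 240-fold (2.38 log units) apart, beyond the scatter of two such steps. The two changes therefore do not act independently across these four compounds, but the data show neither the reason nor any rule beyond them.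

As far as these compounds go, it remains open whether an unsubstituted phenyl on the sulfonyl sulfur, or bromo in place of chloro, would follow compound 1 or compound 3. Whether the reversal holds for any further pair is also unsettled.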